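A Longer Chain on a Compound at the Assay Limit

The source may report more compounds than this note shows. Statements on the series, on what has been measured and on what is new or still open speak of the compounds shown alone.

Of the compounds shown here, three sharing one core have been tested in a functional assay on A549 cells (Homo sapiens) for inhibition, read by MTT assay, with a stated time of 24 h; on this read-out higher numbers stand for weaker inhibition and lower numbers for stronger inhibition. Compound 1 `CCCc1cc2ccccc2nc1-c1cc(-c2ccccc2)no1` gives 52500 nM in this assay. Compound 2 `CCCc1cc2ccccc2nc1-c1cc(-c2ccc(F)cc2)no1` gives 51300 nM in this assay. Going by the values given here, the step of a 1.0-fold lower number from compound 1 to compound 2 (0.01 log units; within the scatter) is the only measured step that can be read as a single change. Compound 3 `CCc1cc2ccccc2nc1-c1cc(-c2ccc(C(F)(F)F)cc2)no1` carries a trifluoromethyl group and an ethyl chain, and in this assay compound 3 gives only > 100000 nM, which is a limit of the assay rather than a number. Among the compounds with values here, it is the one value sitting at the limit of > 100000 nM in this assay, at which 1 of the 3 values shown sits, so compound 3 stands at the limit, the only compound to do so.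

Compound 4 `CCCc1cc2ccccc2nc1-c1cc(-c2ccc(C(F)(F)F)cc2)no1` differs from compound 3 by methyl in place of hydrogen on a saturated chain carbon, two bonds along the chain from an aromatic carbon, turning ethyl into propyl. Within the data shown here, none of the measured steps touches this chain; the single measured step, fluoro for hydrogen on an aromatic carbon, lies within the scatter. There is thus no ground to expect a step beyond the scatter, and the expected step that the limit leaves unreadable from compound 3 to compound 4 is set accordingly. Compound 4 is estimated at 120000 nM, between 50000 nM and 300000 nM, with a fair chance that this assay again reports only a limit.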

Compound 4, half-maximal inhibitory concentration: 43900 nM
Beside the measured number, compound 4's estimate is 2.7-fold (0.44 log units) above it; measured number outside the range, below it.
By their numbers in this assay, from the lowest: compounds 4, 2 and 1 (each within the scatter of the next). At a limit, above all of these: compound 3.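

Going by these compounds alone, the change from ethyl to propyl gives an at least 2.2-fold lower number from compound 3 to compound 4 (0.35 log units; beyond the scatter), the first step that lies beyond the scatter in this assay, and it shows that this saturated chain carbon can respond to a single added methyl. The value of compound 3 is a limit of the assay and not a number, so the true size of this step stays unknown and only its minimum can be read: the limit of > 100000 nM in this assay, at which 1 of the 4 values shown sits.

With the propyl chain kept, the group on the aromatic carbon makes no visible difference, since trifluoromethyl gives a 1.2-fold lower number from compound 2 to compound 4 (0.07 log units; within the scatter) and a 1.2-fold lower number from compound 1 to compound 4 (0.08 log units; within the scatter), both within the scatter.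

As far as these compounds go, the ethyl chain appears here only in compound 3, so it remains open whether shortening the chain would have the same effect with hydrogen or fluoro on the aromatic carbon in place of trifluoromethyl. Also open, from the compounds shown here alone, is how the number in this assay would respond to a longer chain such as butyl, or to a chain carrying an amine, and so whether the trend from ethyl to propyl continues beyond these compounds.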